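A phenyl group swap in an antiproliferative series

This account rests on a few compounds, and the source may have more. Where it says the series, first, only, none or still open, it means among the compounds named here.

Among the measured compounds shown here, in a functional assay on KB cells (Homo sapiens) for antiproliferative activity, read by sulforhodamine B assay, with a stated time of 3 days (on this read-out lower numbers stand for an effect already at smaller amounts and higher numbers for an effect only at larger amounts of compound), compound 2 (`CCC1=C(O)c2c(oc(-c3ccc(OC)c(Cl)c3)cc2=O)C(CC)(CC)C1=O`) gives 24.9 uM, the only true number so far. Compound 1 (`CCOc1ccc(-c2cc(=O)c3c(o2)C(CC)(CC)C(=O)C(CC)=C3O)cc1`) reports only a limit, > 52.4 uM.

Compound 3 (`CCC1=C(O)c2c(oc(-c3ccc(F)c(C)c3)cc2=O)C(CC)(CC)C1=O`) has not yet been measured. It differs from compound 2 in one group: 4-fluoro-3-methylphenyl in place of 3-chloro-4-methoxyphenyl on an aromatic carbon. The core stays the same, and the swap happens on the aromatic carbon next to the ring oxygen.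

For the measured compounds named here, only one measured step bears on this change. It altered the group at that same carbon and gave an at least 2.1-fold lower number from compound 1 to compound 2 (0.32 log units; beyond the scatter), which is a modest change. A single step cannot show which groups at this place do better, so it gives no direction for the new swap. A shift of similar size either way remains possible, and so does another limit. Overall, no clear step beyond the scatter is expected in this assay, with only a slight lean towards a higher number. The expected change is a 1.2-fold higher number from compound 2 to compound 3 (0.08 log units; within the scatter). For compound 3 the estimated value is 30 uM, with an expected range from 13 uM to 60 uM.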

Compound 3, concentration for half-maximal effect: 40.5 uM
Compound 3: the middle estimate sits 1.4-fold (0.13 log units) below what was measured, within the range that was stated.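

In this assay, 4-fluoro-3-methylphenyl in place of 3-chloro-4-methoxyphenyl on the aromatic carbon next to the ring oxygen gives a 1.6-fold higher number from compound 2 to compound 3 (0.21 log units; within the scatter), so two phenyl groups with different substituents cannot be told apart here. Set against the 4-ethoxyphenyl group, the same new group gives an at least 1.2-fold lower number from compound 1 to compound 3 (0.11 log units; that floor lies within the scatter), so unlike the earlier step from compound 1 to compound 2, this comparison does not establish a difference beyond the scatter. Compound 1 has only a limit, so the full size of its steps to the other compounds stays unknown: the limit of > 52.4 uM in this assay, at which 1 of the 3 values shown sits.

The swap from compound 2 to compound 3 changes both ring substituents at once, so the separate contributions of the chlorine, methoxy, fluorine and methyl groups remain unresolved. All three compounds also carry a substituted phenyl group at this carbon, which leaves open how a phenyl ring bearing an amine or a carboxylic acid, or a longer chain in place of the ring, would read in this assay.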